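Fluoro to trifluoromethoxy in a small anilide series

This account rests on a few compounds, and the source may have more. Where it says the series, first, only, none or still open, it means among the compounds named here.

Compound 1 `O=C(CCCCC1CCSS1)Nc1ccc(OC(F)(F)F)cc1`: 0.29%
Compound 2 `O=C(CCCCC(S)CCS)Nc1ccc(Cl)cc1`: 0.27%
Compound 3 `O=C(CCCCC(S)CCS)Nc1ccc(F)cc1`: "not active" (no number reported)

All three compounds were tested in a functional assay on Bel-7402 cells (Homo sapiens) for inhibition, read by MTT assay, with a stated time of 24 h, tested at 1 ug/mL; a higher number here means more inhibition of growth at the concentration tested, a lower number less inhibition of growth. Among the compounds with values here, compound 3 is reported as "not active" (no number reported) in this assay, with no number, so it has no exact place on the scale and no step from it can be calculated. Within the data shown here, compound 1 and compound 2 give the only numbers, and these two values lie within the usual scatter of each other. With so few data points, no trend can be drawn across the series.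

The next compound is compound 4 `O=C(CCCCC(S)CCS)Nc1ccc(OC(F)(F)F)cc1`, which carries trifluoromethoxy in place of fluoro on an aromatic carbon, para to a large group: trifluoromethoxy in place of fluoro on an aromatic carbon. Among the measured compounds shown here, the data hold no measured example of this exchange, so its size can only be judged from the level of the series. In this assay, compound 1 stands at 0.29% and compound 2 stands at 0.27%, and on these values no step beyond the scatter is expected, in either direction. A report without a number would also be unsurprising. For compound 4 the estimated value is 0.3%, with an expected range of 0.1% to 0.6%.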

Compound 4, percent growth inhibition at one concentration: 7.32%
The estimate for compound 4 lay 7 percentage points below the measured number, outside the stated range (above it).
By their numbers in this assay, from the lowest: compounds 2, 1 and 4 (each within the scatter of the next).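

On the aromatic carbon para to a large group, trifluoromethoxy in place of chloro in this assay gives a number 7.1 percentage points higher from compound 2 to compound 4 (within the scatter), so this exchange does not separate the two anilides at this single concentration. With trifluoromethoxy held constant, the open-chain group in place of the group with the five-membered non-aromatic ring, on the saturated chain carbon four bonds along the chain from a carbonyl carbon, gives a number 7 percentage points higher from compound 1 to compound 4 (within the scatter), so opening the ring is likewise not resolved from the scatter here. The step for fluoro to trifluoromethoxy cannot be read, as compound 3 carries no number on this scale, and no measurement available here accounts for any of these results.

The compounds shown leave open how an amine or a carboxylic acid would read out on the same aromatic carbon, as no group of either kind appears there in this set. They also leave open what a longer chain between the carbonyl and the sulfur-bearing end would do, and whether the fluoro, chloro and trifluoromethoxy anilides would separate at any other concentration.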